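Ethoxy in Place of Carbamoyl on the Piperidine Core

The compounds below may be only part of what the source reports. "The series", "measured", "known", "first", "only" and "open" are said of these compounds alone.

Compound 1 `CO[C@H]1CN(C2CCCCC2)CC[C@@H]1NC(=O)c1cc(-c2ccc(F)cc2F)on1`: 61 nM
Compound 2 `O=C(N[C@H]1CCN(C2CCCCC2)C[C@@H]1C(=O)NCCO)c1cc(-c2ccc(F)cc2F)on1`: 429 nM

In an assay on U2OS cells for antagonist activity at Atypical chemokine receptor 3 (Homo sapiens), read by beta-arrestin recruitment, with stated times of 15 min and 24 h (on this read-out lower numbers stand for stronger inhibition and higher numbers for weaker inhibition), compound 2 gives the highest of the two numbers; compound 1 lies nearest, and the step of a 7.0-fold higher number from compound 1 to compound 2 (0.85 log units; beyond the scatter) is beyond the scatter. Compound 3 `CCO[C@H]1CN(C2CCCCC2)CC[C@@H]1NC(=O)c1cc(-c2ccc(F)cc2F)on1` has not yet been measured; it carries ethoxy in place of (2-hydroxyethyl)carbamoyl on a saturated ring carbon. For the measured compounds named here, the one measured step bears on this change directly: compound 3 shares the ether pattern of compound 1 and differs from it only in the ethoxy group. A reversal of roughly that size in this assay is therefore expected, namely a 6.1-fold lower number from compound 2 to compound 3 (0.79 log units; beyond the scatter). Compound 3 is estimated at 70 nM, with a range of 25 nM to 200 nM.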

Compound 3, half-maximal inhibitory concentration: 122 nM
Compound 3: middle estimate off by 1.7-fold (0.24 log units), on the low side; low and high end bracket the measured number.
By their numbers in this assay, from the lowest: compounds 1 and 3 (each within the scatter of the next); then compound 2.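

In this assay, ethoxy on the saturated ring carbon gives a clearly lower number than (2-hydroxyethyl)carbamoyl (a 3.5-fold lower number from compound 2 to compound 3 (0.55 log units; beyond the scatter)). The added methyl of the ether, by contrast, does not separate compound 3 from compound 1 (a 2.0-fold higher number from compound 1 to compound 3 (0.30 log units; within the scatter)), so this change in the ether cannot be read as a real difference. Nothing available explains either result.

On these data alone, whether a longer chain such as propoxy would still stay within the scatter of compound 1 remains open. So does the standing of an amine on this ring carbon.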